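The compounds below may be only part of what the source reports. "The series", "measured", "known", "first", "only" and "open" are said of these compounds alone.

Measured so far:
Compound 1 `COc1ccc2nc(Cl)c(/C=C\c3ccc(F)cc3)cc2c1`: 19200 nM
Compound 2 `FC(F)(F)c1cccc(/C=C\c2cc3ccccc3nc2Cl)c1`: 6150 nM
Compound 3 `FC(F)(F)c1cccc(/C=C/c2cc3ccccc3nc2Cl)c1`: 24700 nM

In an ADME assay on 184B5 cells (Homo sapiens) for antiproliferative activity, read by sulforhodamine B assay, with a stated time of 72 h (on this read-out higher numbers stand for weaker inhibition and lower numbers for stronger inhibition), compound 2 gives 6150 nM, the lowest of the three numbers. Compound 1 stands nearest to it and compound 3 furthest.

Compound 4 `COc1ccc2nc(Cl)c(/C=C\c3cccc(C(F)(F)F)c3)cc2c1` is the next to be read. It is compound 2 with one change, (methoxy in place of hydrogen on an aromatic carbon), that is, methoxy in place of hydrogen on an aromatic carbon. It keeps the Z double bond and the trifluoromethyl group of compound 2.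

Within the data shown here, no measured step isolates this change. The only step available is a 4.0-fold higher number from compound 2 to compound 3 (0.60 log units; beyond the scatter), and it concerns something else, as shown by the fact that compounds 2 and 3 differ only in the configuration as drawn. It therefore offers only a sense of how large a step can be in this small set. The nearest guide is compound 1, which also carries the methoxy group and the Z double bond but has fluorine instead of trifluoromethyl, and it gives 19200 nM. That value leaves room for a rise, though it cannot separate the two differences.

The expected outcome is therefore a small upward move or none beyond the scatter, and the estimated step is a 1.3-fold higher number from compound 2 to compound 4 (0.11 log units; within the scatter). For compound 4 the estimated value is 8000 nM, with an expected range from 2500 nM to 25000 nM.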

Compound 4, half-maximal inhibitory concentration: 5580 nM
Beside the measured number, compound 4's estimate is 1.4-fold (0.16 log units) above it; low and high end bracket the measured number.
By their numbers in this assay, from the lowest: compounds 4 and 2 (each within the scatter of the next); then compounds 1 and 3 (each within the scatter of the next).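

Among these compounds, this is the first step in the set that isolates methoxy in place of hydrogen on an aromatic carbon, and in this assay it reads a 1.1-fold lower number from compound 2 to compound 4 (0.04 log units; within the scatter), so the change does not register at this read-out. With the Z double bond and the trifluoromethyl group held fixed, this position, on a six-membered aromatic ring of carbon only that is part of a fused or bridged system of two rings, takes a methoxy group and its 2 heavy atoms with no reading that can be told apart from that of compound 2. No measurement at hand bears on why this step comes out as it does.

Whether methoxy would behave the same way with the E double bond, or with a group other than trifluoromethyl on the far ring, stays open, as no single step among these compounds tests either case. How an amine, a carboxylic acid or a longer chain such as butoxy would read at this same aromatic carbon also remains an open question.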